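A few compounds are considered here, and "the series" means these few. Any claim that something is new, unique, unknown or untested is made for them only; others in the source may bear on it.

Compound 1, with the structure `COC(=O)C1=C(C)N(c2ccccc2)C=C(C)C1c1ccccc1`, gives -21.1% in a functional assay, tested at 100 ug/mL (on this read-out lower numbers stand for a stronger effect and higher numbers for a weaker effect at the one concentration tested), at the single concentration tested. Compound 2 has the structure `COC(=O)C1=C(C)N(c2cccc(Cl)c2)C=C(C)C1c1ccccc1` and gives -21.3% in this assay as well. The only difference between the two is chloro in place of hydrogen on an aromatic carbon, and the step it makes is a number 0.2 percentage points lower from compound 1 to compound 2 (within the scatter) in size. Compound 3, whose structure is `CC1=C(C(=O)OC(C)(C)C)C(c2ccccc2)C=CN1c1ccccc1`, gives -30.7% in this assay too; how its core differs from that of compound 1 is not broken down here, and its value sits within the usual scatter of those of compound 1 and compound 2. Compound 4 has the structure `CC1=C(C(=O)OC(C)(C)C)C(c2ccccc2)C=CN1c1ccc(Cl)cc1` and has not yet been measured. It differs from compound 3 by chloro in place of hydrogen on an aromatic carbon only. Going by the values given here, this is the same kind of change as the one from compound 1 to compound 2, but there the entering group sits meta to a large group, whereas here it sits para to a large group. The step from compound 3 to compound 4 is expected to be a number 0.3 percentage points lower from compound 3 to compound 4 (within the scatter) in this assay, because the earlier step was a number 0.2 percentage points lower from compound 1 to compound 2 (within the scatter) and stayed within the scatter. Compound 4 is therefore estimated to give -31% in this assay, with a likely range from -45% to -17% around it.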

Compound 4, a percentage reported as activity, at one concentration (the size of the read-out at that concentration, not a potency): -24.5%
Estimate against measurement, compound 4: 6.5 percentage points below; the measured number falls inside the stated range.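

In this assay, putting chloro in place of hydrogen on the aromatic ring of a second core gives a step of a number 6.2 percentage points higher from compound 3 to compound 4 (within the scatter). Set beside the same change on the first core, this step shows no difference between the two cores: the same change on two cores in this assay, a number 0.2 percentage points lower (within the scatter) from compound 1 to compound 2 and a number 6.2 percentage points higher (within the scatter) from compound 3 to compound 4, 6.4 percentage points apart, within the scatter of two such steps. So in these two pairs the change carries over in the sense that it leaves the read-out within the scatter on both cores, but neither pair shows that chloro has any effect of its own, and two pairs cannot establish a rule for the series, especially as the chloro does not occupy the same place on the ring in both.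

As far as these compounds go, it remains open whether a different group on this ring, such as an amine, a methoxy group or a carboxylic acid, would produce a step beyond the scatter. If one did, it would also remain to be seen whether that larger step held its size from one core to the other.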